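The compounds below may be only part of what the source reports. "The series", "measured", "known", "first", "only" and "open" are said of these compounds alone.

Measured compounds and their values:
Compound 1, `CCCCCCCCCCCCCCCCCC/N=c1\nc(N)c2nc[nH]c2c(N)n1`: in a functional assay on A549 cells (Homo sapiens) for antiproliferative activity, read by WST assay, with a stated time of 72 h (on this read-out lower numbers stand for stronger inhibition and higher numbers for weaker inhibition), compound 1 gives 1850 nM.
Compound 2, `CCCCCCCC/N=c1\nc(N)c2ncn(Cc3ccc(F)cc3)c2c(N)n1`: in this assay compound 2 gives 5900 nM.
Compound 3, `CC/N=c1\nc(N)c2nc[nH]c2c(N)n1`: in this assay compound 3 gives 38000 nM.

Compound 3 stands at the highest number of the three, and both gaps to it lie beyond the usual scatter: compound 2 comes nearest, while compound 1 lies furthest away. The step under study leads from compound 3 to compound 4, `CCCCCCCC/N=c1\nc(N)c2nc[nH]c2c(N)n1`. The change is hexyl in place of hydrogen on a saturated chain carbon, two bonds along the chain from a double-bonded nitrogen. Within the data shown here, no measured pair shows this exact step. What can be read is that compound 1, carrying a far longer chain at this position, gives 1850 nM, well below the number of compound 3. Compound 2 carries the same chain length as compound 4 but a differently substituted core, and in this assay compound 2 gives 5900 nM. On that basis the step is expected to lower the number beyond the scatter, though not by the full distance seen for compound 1. Compound 4 is therefore estimated at 5000 nM, with a range from 1500 nM to 15000 nM, the expected step being a 7.6-fold lower number from compound 3 to compound 4 (0.88 log units; beyond the scatter).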

Compound 4, half-maximal inhibitory concentration: "not active" (no number reported)
Compound 4: no number reported; the estimate stays without a comparison.
By their numbers in this assay, from the lowest: compound 1; then compound 2; then compound 3.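

Among these compounds, compound 4 is reported as not active in this assay without a number, so no step from compound 3 to compound 4 can be read. No supporting evidence bears on this result. The compounds shown leave open how hexyl in place of hydrogen alone changes the number.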